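The source may hold more compounds than are shown below. What is called first, only, known or untested is meant among the compounds shown, and "the series" means these compounds.

Measured so far:
- compound 1, `CO[C@@H]1C[C@@H]2[C@H]([C@]1(N)C(=O)O)[C@@]2(F)C(=O)O`: 39.2 nM
- compound 2, `N[C@]1(C(=O)O)[C@H]2[C@@H](C[C@H]1OCc1ccccc1Cl)[C@]2(F)C(=O)O`: 4.99 nM

The read-out throughout is an assay on CHO cells for binding affinity to metabotropic glutamate receptor 2 (Rattus norvegicus); on this read-out lower numbers stand for stronger inhibition and higher numbers for weaker inhibition. Compound 1 carries the highest of the two numbers recorded; its nearest neighbour is compound 2, reached by a 7.9-fold lower number from compound 1 to compound 2 (0.90 log units; beyond the scatter). That single step is the only one available, and it is the one that bears on the question here.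

Compound 3, `N[C@]1(C(=O)O)[C@H]2[C@@H](C[C@H]1OCc1cccc(Br)c1)[C@]2(F)C(=O)O`, has not yet been measured in this assay. It differs from compound 1 by 3-bromophenyl in place of hydrogen on a saturated chain carbon bound to an oxygen on a saturated carbon. Going by the values given here, the change is of the same kind as the one separating compound 1 from compound 2, with a different substituent on the aromatic ring and at a different position of it, so the measured step is a guide rather than a template. Given that compound 2 moved by a 7.9-fold lower number from compound 1 to compound 2 (0.90 log units; beyond the scatter), a step of comparable size and in the same direction is expected for compound 3, with wider uncertainty because the aromatic substitution pattern is not the same. On that basis compound 3 is estimated at 6 nM, within a range of 2 nM to 20 nM, corresponding to an expected step of a 6.5-fold lower number from compound 1 to compound 3 (0.82 log units; beyond the scatter).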

Compound 3, inhibition constant: 4.71 nM
Compound 3: the middle estimate sits 1.3-fold (0.11 log units) above what was measured; measured number inside the range.
By their numbers in this assay, from the lowest: compounds 3 and 2 (each within the scatter of the next); then compound 1.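

In this assay, the gain seen with the 2-chlorophenyl group in a 7.9-fold lower number from compound 1 to compound 2 (0.90 log units; beyond the scatter) is not confined to that one group: 3-bromophenyl on the same saturated chain carbon bound to an oxygen gives an 8.3-fold lower number from compound 1 to compound 3 (0.92 log units; beyond the scatter), also beyond the scatter. The exchange of 2-chlorophenyl for 3-bromophenyl gives a 1.1-fold lower number from compound 2 to compound 3 (0.03 log units; within the scatter), which lies within the scatter, so this position tolerates a change of both the halogen and its place on the aromatic ring without a readable difference in this read-out. Nothing at hand offers an explanation for the gain over compound 1 or for the match between compound 2 and compound 3.

Both aryl groups shown carry a halogen, and they differ in the halogen and in its place on the ring together, so the contribution of the ring, of the halogen and of its placement cannot be separated. From the compounds shown here alone, what an unsubstituted phenyl, a methoxy group on the ring or a longer chain between the oxygen and the ring would give at this position remains open.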